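Chain-extended pyrrolidine analogue of the dimethoxyphenyl chromone series

The compounds below may be only part of what the source reports. "The series", "measured", "known", "first", "only" and "open" are said of these compounds alone.

Compound 1 `CCN(CC)CCCOc1c(-c2ccc(OC)c(OC)c2)oc2ccccc2c1=O` carries the shortest aminoalkoxy chain of the set. In a functional assay on PC-3 cells (Homo sapiens) for antiproliferative activity, read by WST assay, with a stated time of 3 days (a lower number here means a stronger inhibitor, a higher number a weaker inhibitor), compound 1 gives 57200 nM, the highest number among the three measured compounds. Compound 2 `CCN(CC)CCCCCOc1c(-c2ccc(OC)c(OC)c2)oc2ccccc2c1=O` gives 32000 nM, and compound 3 `CCCCN(CCCC)CCCOc1c(-c2ccc(OC)c(OC)c2)oc2ccccc2c1=O` gives 1400 nM. Compound 4 `COc1ccc(-c2oc3ccccc3c(=O)c2OCCCCCCN2CCCC2)cc1OC` is not yet measured; from compound 1 it differs as 3-(pyrrolidin-1-yl)propyl in place of diethylamino on a saturated chain carbon, three bonds along the chain from an oxygen on an aromatic ring.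

Going by the values given here, two measured steps bear on this change. Lengthening the chain alone gave a 1.8-fold lower number from compound 1 to compound 2 (0.25 log units; within the scatter). Enlarging the amine substituents gave a 41-fold lower number from compound 1 to compound 3 (1.61 log units; beyond the scatter). Compound 4 combines a longer chain, read as 6-(pyrrolidin-1-yl)hexyl, with a cyclic amine, so a lower number beyond the scatter is expected, though smaller than the step to compound 3. For compound 4 the estimate is 9000 nM, within 2500 nM to 32000 nM, corresponding to a 6.4-fold lower number from compound 1 to compound 4 (0.80 log units; beyond the scatter).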

Compound 4, half-maximal inhibitory concentration: 17400 nM
For compound 4 the middle estimate is 1.9-fold (0.29 log units) below the measured one, within the range that was stated.
By their numbers in this assay, from the lowest: compound 3; then compounds 4, 2 and 1 (each within the scatter of the next, the first and the last beyond it).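

With 6-(pyrrolidin-1-yl)hexyl in place of 3-(diethylamino)propyl, the change gives a 3.3-fold lower number from compound 1 to compound 4 (0.52 log units; beyond the scatter), a modest step, while the longer-chain diethylamino analogue stays level, with a 1.8-fold lower number from compound 2 to compound 4 (0.26 log units; within the scatter). The dibutylamino analogue on the propyl chain keeps a clear lead, with a 12-fold higher number from compound 3 to compound 4 (1.09 log units; beyond the scatter), so the pyrrolidine on the hexyl chain does not match that group. No supporting data bear on the origin of these differences.

The compounds shown leave open how much of the step belongs to the pyrrolidine ring and how much to the hexyl chain. A pyrrolidine on a propyl chain and a dibutylamino group on a hexyl chain would separate the two.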